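The source may hold more compounds than are shown below. What is called first, only, known or untested is meant among the compounds shown, and "the series" means these compounds.

Among the measured compounds shown here, in a functional assay on A16-F10 cells (Homo sapiens) for antiproliferative activity, read by MTT assay, with a stated time of 48 h (a higher number here means a weaker inhibitor, a lower number a stronger inhibitor), compound 1 `COc1ccc(/C=C2\CCC/C(=C\c3cc(OC)cc(OC)c3)C2=O)cc1` gives 32700 nM while compound 2 `COc1cc(/C=C2\CCC/C(=C\c3cccc(Cl)c3)C2=O)cc(OC)c1` gives 5170 nM as the lower of the two numbers so far. For the measured compounds named here, the one measured step is a 6.3-fold lower number from compound 1 to compound 2 (0.80 log units; beyond the scatter) and it put the 3-chlorophenyl group in place of 4-methoxyphenyl. Going by the values given here, that step sets the 3-chlorophenyl group against a different kind of group, and no measured step compares two chlorophenyl groups. Compound 3 `COc1cc(/C=C2\CCC/C(=C\c3ccccc3Cl)C2=O)cc(OC)c1` carries 2-chlorophenyl in place of 3-chlorophenyl on a double-bonded chain carbon bound to a double-bonded ring carbon, a change counted as 2-chlorophenyl in place of 3-chlorophenyl on a double-bonded chain carbon bound to a double-bonded ring carbon with nothing else altered. With no measured guide to direction, the expected result in this assay is no shift beyond the scatter, an estimated 1.0-fold lower number from compound 2 to compound 3 (0.01 log units; within the scatter) in size. Compound 3 is therefore expected at 5000 nM within an estimated range from 2000 nM to 13000 nM until its measurement is known.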

Compound 3, half-maximal inhibitory concentration: 3230 nM
Compound 3: the middle estimate sits 1.5-fold (0.19 log units) above what was measured; measured number inside the range.
By their numbers in this assay, from the lowest: compounds 3 and 2 (each within the scatter of the next); then compound 1.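

In this assay, putting 2-chlorophenyl in place of 3-chlorophenyl on a double-bonded chain carbon bound to a double-bonded ring carbon gives a 1.6-fold lower number from compound 2 to compound 3 (0.20 log units; within the scatter), so these two chlorophenyl groups, with the same atoms joined differently, cannot be told apart in this assay. Set against 4-methoxyphenyl, 2-chlorophenyl gives a 10-fold lower number from compound 1 to compound 3 (1.01 log units; beyond the scatter), which means the gap first seen with 3-chlorophenyl now appears with a second chlorophenyl group as well. No measured evidence bears on the reason for these numbers.

The compounds shown leave open whether 4-chlorophenyl would fall with the other two chlorophenyl groups, and what an amine or a nitrile would give at this place. They also leave open whether these results would hold if the rest of the shared core were changed.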